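The compounds below may be only part of what the source reports. "The series", "measured", "known", "first", "only" and "open" are said of these compounds alone.

Compound 1 `CCc1cn([C@H]2C[C@H](N=[N+]=[N-])[C@@H](CO)O2)c(=O)[nH]c1=O`: > 100 ug/mL
Compound 2 `[N-]=[N+]=N[C@H]1C[C@H](n2cc(Cl)c(=O)[nH]c2=O)O[C@@H]1CO`: > 100 ug/mL
Compound 3 `CCc1cn([C@H]2C[C@H](I)[C@@H](CO)O2)c(=O)[nH]c1=O`: > 100 ug/mL

In an ADME assay on Huh-7 cells (Homo sapiens) for cytotoxicity, read by XTT assay (a lower number here means that less compound is tolerated, a higher number that more compound is tolerated), compound 2 gives > 100 ug/mL, which is a limit of the assay and not a number. It is not alone there, as the series shows (the limit of > 100 ug/mL in this assay, at which 3 of the 3 values shown sit). Compound 4 `[N-]=[N+]=N[C@H]1C[C@H](n2cc(F)c(=O)[nH]c2=O)O[C@@H]1CO` departs from compound 2 by a single exchange: fluoro in place of chloro on an aromatic carbon. The measured step closest to it, also on an aromatic carbon, is a step that the two limits leave unreadable from compound 1 to compound 2. The other, on a saturated ring carbon, is a step that the two limits leave unreadable from compound 1 to compound 3. Neither yields a size, so no step beyond the scatter is expected in this assay, and no direction can be assigned. The expected outcome is a number no higher from compound 2 to compound 4 (the limit leaves the size open). Compound 4 is expected at 100 ug/mL, with an estimated range from 40 ug/mL to 200 ug/mL.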

Compound 4, half-maximal cytotoxic concentration: > 100 ug/mL
Compound 4 ended at the assay's limit; the forecaster's own chance of this, stated with the estimate: 75%; the middle value sits exactly at the limit.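

In this assay compound 4 gives > 100 ug/mL, which is a limit and not a number. For the compounds shown here, no step from compound 1 or compound 2 to compound 4 can be read. The compounds shown leave open how far apart any of them lie in this assay, as all share one limit: the limit of > 100 ug/mL in this assay, at which 4 of the 4 values shown sit.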